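A few compounds are considered here, and "the series" means these few. Any claim that something is new, unique, unknown or untested is made for them only; others in the source may bear on it.

In a functional assay on L1210 cells (Mus musculus) for inhibition (a higher number here means a weaker inhibitor, a lower number a stronger inhibitor), compound 1 `Nc1ncnc2c1ncn2C/C=C/CCl` gives 45000 nM. For compound 2 `Nc1ccn(C/C=C\CO)c(=O)n1` the result is a limit and not a number: > 1000000 nM. Compound 3 `Nc1ccn(C=C=CCO)c(=O)n1` gives 560000 nM, the higher of the two numeric values, and its gap to compound 1 lies beyond the scatter. Compound 4 `Cc1cn(C=C=CCO)c(=O)nc1N` differs from compound 3 by one change: methyl in place of hydrogen on an aromatic carbon. Among the compounds with values here, no measured pair shows this change, so the expectation rests on compound 3 at 560000 nM. The expected result in this assay is a 1.1-fold lower number from compound 3 to compound 4 (0.05 log units; within the scatter), with no clear direction and no step beyond the scatter. For compound 4 the estimate is 500000 nM, with an expected range of 170000 nM to 1000000 nM.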

Compound 4, half-maximal inhibitory concentration: 620000 nM
For compound 4 the middle estimate is 1.2-fold (0.09 log units) below the measured one; measured number inside the range.
By their numbers in this assay, from the lowest: compound 1; then compounds 3 and 4 (each within the scatter of the next). At a limit, above all of these: compound 2.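

In this assay, methyl in place of hydrogen on an aromatic carbon, ortho to an amino group, gives a 1.1-fold higher number from compound 3 to compound 4 (0.04 log units; within the scatter). Within the data shown here, this is the first one-place comparison, and it shows that this change at this position does not move the read-out beyond the scatter. Compound 2 gives a limit and not a number, which marks the top of the readable range: the limit of > 1000000 nM in this assay, at which 1 of the 4 values shown sits.

Going by these compounds, whether ethyl, chlorine or an amine at this position would shift the number stays open. So does whether methyl behaves the same way on the core of compound 1.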